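Ethoxy in place of methyl on the shared core

The source may hold more compounds than are shown below. What is called first, only, known or untested is meant among the compounds shown, and "the series" means these compounds.

Compound 1 `COc1ccc2nc(NC(=O)CCCCC(=O)NO)sc2c1` — in a functional assay on MCF7 cells (Homo sapiens) for cytotoxicity (a higher number here means a weaker inhibitor, a lower number a stronger inhibitor), compound 1 gives 5.91 ug/mL.
Compound 2 `CS(=O)(=O)c1ccc2nc(NC(=O)CCCCC(=O)NO)sc2c1` — compound 2 reaches only the limit > 30 ug/mL in this assay, a limit and not a number.
Compound 3 `Cc1ccc2nc(NC(=O)CCCCC(=O)NO)sc2c1` — compound 3 gives 4.27 ug/mL in this assay.

Compound 3 stands at the lowest of the two numbers shown, with compound 1 nearest: the step of a 1.4-fold lower number from compound 1 to compound 3 (0.14 log units; within the scatter) lies within the scatter, so the two cannot be ordered. The one limit shown, (the limit of > 30 ug/mL in this assay, at which 1 of the 3 values shown sits), belongs to compound 2, and the step of an at least 7.0-fold lower number from compound 2 to compound 3 (0.84 log units; beyond the scatter) is the only one here beyond the scatter.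

Compound 4 `CCOc1ccc2nc(NC(=O)CCCCC(=O)NO)sc2c1` differs from compound 3 by ethoxy in place of methyl on an aromatic carbon. The step that bears most on this change is the exchange of methoxy for methyl between compound 1 and compound 3, which stayed within the scatter; the methylsulfonyl steps do not concern an alkoxy group. Compound 4 is therefore expected to show a step of a 1.2-fold higher number from compound 3 to compound 4 (0.07 log units; within the scatter) that stays within the scatter. Compound 4 is estimated at 5 ug/mL, between 2.5 ug/mL and 10 ug/mL.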

Compound 4, half-maximal inhibitory concentration: 8.72 ug/mL
Beside the measured number, compound 4's estimate is 1.7-fold (0.24 log units) below it; the measured number falls inside the stated range.
By their numbers in this assay, from the lowest: compounds 3, 1 and 4 (each within the scatter of the next, the first and the last beyond it). At a limit, above all of these: compound 2.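

In this assay, among these compounds, ethoxy in place of methyl gives a modest step that passes the scatter (a 2.0-fold higher number from compound 3 to compound 4 (0.31 log units; beyond the scatter)), the first among the small groups at this position to do so. Going from methoxy to ethoxy, with one added methyl on the saturated chain carbon bound to the oxygen, stays within the scatter (a 1.5-fold higher number from compound 1 to compound 4 (0.17 log units; within the scatter)), so these two alkoxy compounds cannot be ordered. The step from methylsulfonyl to ethoxy lies beyond the scatter (an at least 3.4-fold lower number from compound 2 to compound 4 (0.53 log units; beyond the scatter)), and compound 2 stands at a limit, not a number: the limit of > 30 ug/mL in this assay, at which 1 of the 4 values shown sits.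

As far as these compounds go, whether a longer chain such as propoxy would raise the number further remains open. So does whether an amine or a carboxylic acid on this aromatic carbon would fall with the alkyl and alkoxy groups or with methylsulfonyl.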